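This account rests on a few compounds, and the source may have more. Where it says the series, first, only, none or still open, it means among the compounds named here.

Values measured in an ADME assay on SH-SY5Y cells (Homo sapiens) for cytotoxicity, read by MTT assay, with a stated time of 72 h; a higher number here means a weaker inhibitor, a lower number a stronger inhibitor:
- compound 1 `O=C(CN1CCN(C(=O)c2cccc(Br)c2)CC1)N1CCN(CCCc2c[nH]c3ccccc23)CC1`: 80500 nM
- compound 2 `O=C(CN1CCN(C(=O)c2ccc(F)cc2)CC1)N1CCN(CCCc2c[nH]c3ccc(F)cc23)CC1`: 121000 nM
- compound 3 `O=C(CN1CCN(C(=O)c2cccc(Cl)c2)CC1)N1CCN(CCCc2c[nH]c3ccc(F)cc23)CC1`: 59800 nM

Compound 3 gives 59800 nM, which lies within the usual scatter of the value for compound 1, 80500 nM. Compound 2 stands clearly apart from it, and the step is a 2.0-fold lower number from compound 2 to compound 3 (0.31 log units; beyond the scatter).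

The next compound to be measured is compound 4 `O=C(CN1CCN(C(=O)c2cccc(Br)c2)CC1)N1CCN(CCCc2c[nH]c3ccc(F)cc23)CC1`. It keeps everything in compound 3 except one halogen: bromo in place of chloro on an aromatic carbon. Put simply, this is bromo in place of chloro on an aromatic carbon.

For the measured compounds named here, no measured pair shows this exact swap, so the evidence is indirect. Going by the values given here, the only measured step, a 2.0-fold lower number from compound 2 to compound 3 (0.31 log units; beyond the scatter), is modest and replaces 4-fluorophenyl with 3-chlorophenyl, a larger change than the one at hand. Compound 1 already carries the 3-bromophenyl group, but it differs from compound 4 elsewhere in the shared core. The value of compound 1, 80500 nM, nevertheless suggests that this group fits within the same range of numbers.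

No step beyond the scatter is therefore expected in this assay, and no direction can be argued with confidence. The expected step is a 1.1-fold higher number from compound 3 to compound 4 (0.04 log units; within the scatter), an estimate that stays within the scatter.

For compound 4 the estimated value is 65000 nM, with an expected range from 35000 nM to 115000 nM.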

Compound 4, half-maximal inhibitory concentration: 71600 nM
Compound 4: the middle estimate sits 1.1-fold (0.04 log units) below what was measured, within the range that was stated.
By their numbers in this assay, from the lowest: compounds 3, 4, 1 and 2 (each within the scatter of the next, the first and the last beyond it).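

In this assay, for the compounds shown here, the first direct look at bromo in place of chloro on this aromatic carbon gives a 1.2-fold higher number from compound 3 to compound 4 (0.08 log units; within the scatter) as its step, so these two halogens cannot be told apart here at this place on the ring. Two further comparisons also stay within the scatter: fluoro in place of hydrogen gives a 1.1-fold lower number from compound 1 to compound 4 (0.05 log units; within the scatter) as its step, and 3-bromophenyl in place of 4-fluorophenyl on the carbonyl carbon gives a 1.7-fold lower number from compound 2 to compound 4 (0.23 log units; within the scatter) as its step, although 3-chlorophenyl in that same exchange gave a 2.0-fold lower number from compound 2 to compound 3 (0.31 log units; beyond the scatter) as a step just beyond it. Compound 2 is therefore clearly set apart from compound 3 only, and nothing among the data shown offers an explanation for any of these steps.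

Going by these compounds, whether a group other than a halogen on this same aromatic carbon, such as a methoxy group, an amine or a carboxylic acid, would shift the number beyond the scatter remains open. Also open, on these data alone, is whether fluoro in place of hydrogen on the shared core would give a similar step alongside a different group on the carbonyl carbon.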